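Notes on the benzyl swap from compound 3 to compound 4

The source may hold more compounds than are shown below. What is called first, only, known or untested is meant among the compounds shown, and "the series" means these compounds.

The series shares one core carrying a sulfonyl-bound nitrogen, an aryl group on that nitrogen and a benzyl group at the far end. In an assay on CHO cells for displacement of a labelled ligand from prostaglandin E2 receptor EP1 subtype (Homo sapiens) (a higher number here means a weaker inhibitor, a lower number a stronger inhibitor), compound 1 `CCc1ccccc1N(Cc1nnc(Cc2ccc(OC)cc2)o1)S(=O)(=O)c1ccc(C)cc1` gives 126 nM; 126 nM (2 entries), and compound 2 `CCOc1ccc(Cc2nnc(CN(c3cccc(Cl)c3Cl)S(=O)(=O)c3ccc(C)cc3)o2)cc1` gives 6.31 nM. Compound 3 `Cc1ccc(S(=O)(=O)N(Cc2nnc(Cc3ccc(F)cc3)o2)c2cccc(Cl)c2C)cc1` gives 200 nM in this assay, the highest of the two single numbers; the nearest single number is that of compound 2, which lies far lower, beyond the scatter. Compound 3 and compound 2 differ in more than one place, so the gap is not attributed to any one change.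

Compound 4 `Cc1ccc(S(=O)(=O)N(Cc2nnc(Cc3c(Cl)cccc3Cl)o2)c2cccc(Cl)c2C)cc1` differs from compound 3 only in the benzyl end: 2,6-dichlorophenyl in place of 4-fluorophenyl on a saturated chain carbon bound to an aromatic carbon. For the measured compounds named here, no measured pair in the set isolates this change, so the direction and size of the step are open. Without such a pair, a step no larger than the scatter is expected from compound 3 to compound 4, a 1.3-fold lower number from compound 3 to compound 4 (0.10 log units; within the scatter), in either direction. Compound 4 is therefore estimated at 160 nM in this assay, within a range of 40 nM to 640 nM.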

Compound 4, half-maximal inhibitory concentration: 63.1 nM
Estimate against measurement, compound 4: 2.5-fold (0.40 log units) above; the measured number falls inside the stated range.
By their numbers in this assay, from the lowest: compound 2; then compound 4; then compound 3.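

For the compounds shown here, the step of a 3.2-fold lower number from compound 3 to compound 4 (0.50 log units; beyond the scatter) in this assay is the first comparison that differs in one place, so it is the first direct reading of the benzyl end on its own. With the rest of the molecule held fixed, this position responds to the change from 4-fluorophenyl to 2,6-dichlorophenyl, and the modest step lies beyond the scatter. Nothing measured here speaks to what lies behind the step.

Since the fluorine leaves and both chlorines enter in one move, the pair cannot separate their contributions; an unsubstituted benzyl, a 2-chlorobenzyl or a 4-chlorobenzyl at this end would divide the step. From the compounds shown here alone, whether the same step holds with a different aryl group on the nitrogen also stays open.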